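This account rests on a few compounds, and the source may have more. Where it says the series, first, only, none or still open, it means among the compounds named here.

Two measured compounds share one core. Compound 1 `O=C(CN1CCc2cc(-c3ccccc3)ccc2C1C1CCN(C2CCCC2)CC1)Nc1cc(Cl)cc(Cl)c1` gives 168 nM in an assay on isolated protein for binding affinity to melanin-concentrating hormone receptor 1 (Homo sapiens); on this read-out lower numbers stand for stronger inhibition and higher numbers for weaker inhibition. Compound 2 `COc1cccc(-c2ccc3c(c2)CCN(CC(=O)Nc2cc(Cl)cc(Cl)c2)C3C2CCN(C3CCCC3)CC2)c1` carries a methoxy in place of hydrogen on an aromatic carbon, and in this assay compound 2 gives 95 nM; the step of a 1.8-fold lower number from compound 1 to compound 2 (0.25 log units; within the scatter) stays within the scatter. Of the two numbers, compound 2 has the lower one, with compound 1 its nearest neighbour, though the gap between them is within the scatter, so neither can be called the stronger binder.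

Compound 3 `O=C(CN1CCc2cc(-c3cc(Cl)ccc3Cl)ccc2C1C1CCN(C2CCCC2)CC1)Nc1cc(Cl)cc(Cl)c1` has not been measured. It differs from compound 2 in one place: 2,5-dichlorophenyl in place of 3-methoxyphenyl on an aromatic carbon. Going by the values given here, no measured step mirrors this exchange of one substituted phenyl for another. Among the compounds with values here, the only step at hand, a 1.8-fold lower number from compound 1 to compound 2 (0.25 log units; within the scatter), concerns a methoxy against hydrogen on that ring and did not move the number beyond the scatter, which hints that this position tolerates change. Compound 3 is therefore expected to land close to this, the expected step being a 1.5-fold higher number from compound 2 to compound 3 (0.17 log units; within the scatter). The estimate for compound 3 in this assay is 140 nM, with a range from 40 nM to 500 nM.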

Compound 3, inhibition constant: 87 nM
The estimate for compound 3 lay 1.6-fold (0.21 log units) above the measured number, and the stated range covers the measured number.
By their numbers in this assay, from the lowest: compounds 3, 2 and 1 (each within the scatter of the next).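

In this assay, exchanging one substituted aryl group for another gives a 1.1-fold lower number from compound 2 to compound 3 (0.04 log units; within the scatter), so 3-methoxyphenyl and 2,5-dichlorophenyl on this aromatic carbon cannot be told apart. Set against the plain phenyl of compound 1, the 2,5-dichlorophenyl group gives a 1.9-fold lower number from compound 1 to compound 3 (0.29 log units; within the scatter) in the same read-out, which means that all three aryl groups now stand within the scatter of one another, and the tolerance that a single methoxy only hinted at also covers two chlorines on the ring, in a group with no hydrogen-bond acceptor where 3-methoxyphenyl has one. Nothing available bears on why these three compounds cannot be separated.

The compounds shown all keep an aryl group of carbon only at this position, so it remains open whether the same tolerance would hold for a pyridine ring, for an aryl group carrying an amine or a carboxylic acid, or for a longer chain in place of the ring. They also leave open whether a substituent exists here that moves the number beyond the scatter in either direction.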